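Replacing 4-Nitrophenyl with 3-Carboxyphenyl: Expected Cytotoxicity

The source may report more compounds than this note shows. Statements on the series, on what has been measured and on what is new or still open speak of the compounds shown alone.

Three compounds have so far been measured in a functional assay on CRL2813 cells (Homo sapiens) for cytotoxicity, read by sulforhodamine B assay, with a stated time of 5 days; on this read-out lower numbers stand for stronger inhibition and higher numbers for weaker inhibition:

Compound 1, `O=C(Nc1cccc(C(F)(F)F)c1)N[C@H]1CC[C@@H](Oc2ccc(F)cc2)CC1`: 2600 nM
Compound 2, `O=C(Nc1ccc([N+](=O)[O-])cc1)N[C@H]1CC[C@H](Oc2ccc(F)cc2)CC1`: 2300 nM
Compound 3, `O=C(Nc1cccc(C(F)(F)F)c1)N[C@H]1CCC[C@H](Oc2ccc(C(F)(F)F)cc2)C1`: 3800 nM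

Compound 2 shows the lowest of the three numbers, but its distances to compound 1 and to compound 3 both lie within the usual scatter, so the three compounds are not separated by these data. Compound 4, `O=C(Nc1cccc(C(=O)O)c1)N[C@H]1CC[C@H](Oc2ccc(F)cc2)CC1`, has not yet been measured. It differs from compound 2 in a single place: 3-carboxyphenyl in place of 4-nitrophenyl on an amide-type nitrogen. For the measured compounds named here, no pair of measured compounds differing in one place is available, so the size of this step rests on judgement alone. In this assay a modest weakening is expected, a 2.2-fold higher number from compound 2 to compound 4 (0.34 log units; beyond the scatter), and it may prove no larger than the scatter. Compound 4 is therefore estimated at 5000 nM, with a range from 2000 nM to 15000 nM.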

Compound 4, half-maximal inhibitory concentration: > 20000 nM
Compound 4: only a limit was reported; the forecaster's own chance of this, stated with the estimate: 15%; middle value at least 4.0-fold (0.60 log units) from the limit.
By their numbers in this assay, from the lowest: compounds 2, 1 and 3 (each within the scatter of the next). At a limit, above all of these: compound 4.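

In this assay, for the compounds shown here, the substituent on the amide-type nitrogen proved able to shift the read-out beyond the scatter, which the earlier compounds, all within the scatter of one another, did not show: 3-carboxyphenyl in place of 4-nitrophenyl gives an at least 8.6-fold higher number from compound 2 to compound 4 (0.93 log units; beyond the scatter). Compound 4 is reported only as a limit: the limit of > 20000 nM in this assay, at which 1 of the 4 values shown sits.

The compounds shown leave open how far this step extends past that limit. They also leave open whether a methyl ester or a primary amide in place of the carboxylic acid would give a similar loss.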